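Swapping the ring on the cyclic amide nitrogen

The source may report more compounds than this note shows. Statements on the series, on what has been measured and on what is new or still open speak of the compounds shown alone.

Compound 2 `O=C(NCCCCc1ccccc1)c1cccc(C2SCC(=O)N2c2ccccn2)c1` carries pyridin-2-yl on the amide-type nitrogen of its five-membered ring. For the measured compounds named here, in a functional assay on HOS-TE85 cells (Homo sapiens) for inhibition, read by CCK-8 assay, with a stated time of 72 h (a higher number here means a weaker inhibitor, a lower number a stronger inhibitor), compound 2 gives 19.7 nM, the only firm number here. Compound 1 `CCN(CC)c1ccc(N2C(=O)CSC2c2cccc(C(=O)NCCCCc3ccccc3)c2)cc1`, with 4-(diethylamino)phenyl in that place, reaches only a limit of the assay, > 1000 nM. The step of an at least 50-fold lower number from compound 1 to compound 2 (1.70 log units; beyond the scatter) shows that this position changes potency strongly. Compound 3 `O=C(NCCCCc1ccccc1)c1cccc(C2SCC(=O)N2c2ccc(C3CC3)cc2)c1` brings the change (4-cyclopropylphenyl in place of pyridin-2-yl on an amide-type nitrogen in a ring), returning to a substituted phenyl as in compound 1. Given the large step of an at least 50-fold lower number from compound 1 to compound 2 (1.70 log units; beyond the scatter), a weakening is expected, estimated as a 15-fold higher number from compound 2 to compound 3 (1.18 log units; beyond the scatter). For compound 3 the estimate is 300 nM, within 60 nM to 1500 nM.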

Compound 3, half-maximal inhibitory concentration in the HOS-TE85 assay: 217 nM
For compound 3 the middle estimate is 1.4-fold (0.14 log units) above the measured one; the measured number falls inside the stated range.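

In the HOS-TE85 assay, compound 1 rests on a limit of the assay, yet a substituted phenyl on this nitrogen can still give a firm number, since cyclopropyl in place of diethylamino gives an at least 4.6-fold lower number from compound 1 to compound 3 (0.66 log units; beyond the scatter). Pyridin-2-yl nevertheless stays ahead of 4-cyclopropylphenyl, with an 11-fold higher number from compound 2 to compound 3 (1.04 log units; beyond the scatter). In a physicochemical assay for solubility, read by turbidimetry, measured as kinetic solubility, at pH 6.8 (a lower number here means a less soluble compound, a higher number a more soluble compound), compound 2 gives 20000 nM, and compound 3 gives 2000 nM. The same change also costs solubility in the physicochemical assay: the measured solubility of compound 2, 20000 nM, and of compound 3, 2000 nM, a 10-fold lower number (1.00 log units; beyond the scatter)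

Still open, as far as these compounds go, is how an unsubstituted phenyl or a pyridin-2-yl bearing cyclopropyl would compare, which would help separate the effect of the ring nitrogen from that of the added group.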